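The source may hold more compounds than are shown below. What is called first, only, known or untested is meant among the compounds shown, and "the series" means these compounds.

Measured so far:
compound 1 `CN(C)CCN(CCN(C)C)c1ccc(C(=O)N2CCc3ccc(OS(N)(=O)=O)cc3C2)cc1`: 15.9%
compound 2 `NS(=O)(=O)Oc1ccc2c(c1)CN(C(=O)c1cccc(N(Cc3ccccc3)Cc3ccco3)c1)CC2`: 90.5%
compound 3 `NS(=O)(=O)Oc1ccc2c(c1)CN(C(=O)c1ccc(N3CCC(N4CCCCC4)CC3)cc1)CC2`: 53.7%

In an assay on HEK293 cells for inhibition of Steryl-sulfatase (Homo sapiens), tested at 1 uM (on this read-out higher numbers stand for a stronger effect at the one concentration tested and lower numbers for a weaker effect), compound 1 gives 15.9%, the lowest of the three numbers. Compound 3 stands nearest, its value of 53.7% lying higher by a margin beyond the scatter, and compound 2 stands furthest with 90.5%, also beyond the scatter. Compound 4 `CN(CCN1CCCCC1)c1ccc(C(=O)N2CCc3ccc(OS(N)(=O)=O)cc3C2)cc1` has not yet been measured. It differs from compound 1 in one place: methyl(2-(piperidin-1-yl)ethyl)amino in place of bis(2-(dimethylamino)ethyl)amino on an aromatic carbon. Among the compounds with values here, no step between two measured compounds isolates this change, so any expectation rests on the spread of the three values alone. A modest rise in this assay is expected for compound 4, a step of a number 14.1 percentage points higher from compound 1 to compound 4 (beyond the scatter), which may not exceed the scatter. Compound 4 is estimated at 30%, within 10% to 55%.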

Compound 4, a percentage reported as inhibition, at one concentration (the size of the read-out at that concentration, not a potency): 26.8%
For compound 4 the middle estimate is 3.2 percentage points above the measured one, within the range that was stated.
By their numbers in this assay, from the lowest: compound 1; then compound 4; then compound 3; then compound 2.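

In this assay, within the data shown here, methyl(2-(piperidin-1-yl)ethyl)amino in place of bis(2-(dimethylamino)ethyl)amino on the aromatic carbon gives a number 10.9 percentage points higher from compound 1 to compound 4 (beyond the scatter) as the first step that isolates one place. Exchanging this open-chain group for one carrying a six-membered non-aromatic ring thus moves the read-out at this position only modestly. No available data bear on the origin of this step. The exchange alters the ring and the chain together, leaving their separate contributions unresolved. Also open, on these data alone, is how a morpholine or a single dimethylamino group would read on this aromatic carbon.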